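Trifluoromethyl to Dichloro on the Outer Ring

The compounds below may be only part of what the source reports. "The series", "measured", "known", "first", "only" and "open" are said of these compounds alone.

Compound 2 `CCOC(=O)CCCCCOc1cccc(CN(C(=O)c2ccc(-c3cccc(C(F)(F)F)c3)cc2)C(C)C)c1` stands at a limit of an ADME assay on BJ cells (Homo sapiens) for cytotoxicity, read by CellTiter-Glo and resazurin assay, with a stated time of 72 h; on this read-out higher numbers stand for an effect only at larger amounts of compound and lower numbers for an effect already at smaller amounts. In this assay compound 2 gives < 1.3 nM, which is a limit and not a number (the limit of < 1.3 nM in this assay, at which 1 of the 2 values shown sits). Compound 1 `CCOC(=O)CCCCCOc1cccc(CN(C(=O)c2ccc(-c3cccc(C(C)=O)c3)cc2)C(C)C)c1` gives > 26000 nM, also a limit (the limit of > 26000 nM in this assay, at which 1 of the 2 values shown sits). Between them lies an at least 20000-fold lower number from compound 1 to compound 2 (4.30 log units; beyond the scatter). Compound 3 `CCOC(=O)CCCCCOc1cccc(CN(C(=O)c2ccc(-c3ccc(Cl)c(Cl)c3)cc2)C(C)C)c1` carries 3,4-dichlorophenyl in place of 3-(trifluoromethyl)phenyl on an aromatic carbon. Going by the values given here, no measured step involves a dichlorophenyl, so the earlier step bears only loosely on this change. A step of an at least 7.6-fold higher number from compound 2 to compound 3 (0.88 log units; beyond the scatter) is expected, with much uncertainty. Compound 3 is therefore estimated at 10 nM, within 1 nM to 500 nM.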

Compound 3, half-maximal effective concentration: > 26000 nM
Compound 3 was reported as a limit; the forecaster's own chance of this, stated with the estimate: 30%; middle value at least 2600-fold (3.41 log units) away from the limit.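

Replacing 3-(trifluoromethyl)phenyl with 3,4-dichlorophenyl on this aromatic carbon gives an at least 20000-fold higher number from compound 2 to compound 3 (4.30 log units; beyond the scatter) in this assay. The earlier compounds shown here tied a high number only to acetyl, but a group with no carbonyl now reaches the same end of the scale, leaving compound 2 alone at the low end. Compound 3 stands at a limit, and it is the same limit as for compound 1: the limit of > 26000 nM in this assay, at which 2 of the 3 values shown sit.

The step from compound 1 to compound 3 cannot be read, as both values are limits. From the compounds shown here alone, how a single chlorine, an amine or a carboxylic acid on this outer ring would read remains open.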